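A few compounds are considered here, and "the series" means these few. Any claim that something is new, unique, unknown or untested is made for them only; others in the source may bear on it.

Compound 1 `c1ccc(Sc2ncnc3[nH]cnc23)cc1` and compound 2 `Fc1ccc(Sc2ncnc3[nH]cnc23)cc1` share one core; compound 3 `Cn1c(-c2ccccc2)nc2c(Sc3ccccc3)ncnc21` and compound 4 `Cn1c(-c2ccccc2)nc2c(Sc3ccc(F)cc3)ncnc21` share another, and the difference between the two cores is not broken down here. In an assay on isolated protein for inhibition of RAC-alpha serine/threonine-protein kinase (Homo sapiens), tested at 30 uM (a lower number here means less inhibition, a higher number more inhibition at the concentration tested (going by the name of the read-out)), compound 1 gives 0%, and compound 2 gives 0%. The change between them, (fluoro in place of hydrogen on an aromatic carbon), produced no change at the digits printed from compound 1 to compound 2 (within the scatter). In this assay compound 3 gives 42%, the highest of the three numbers. The change from compound 3 to compound 4 is the same one, (fluoro in place of hydrogen on an aromatic carbon), made on the second core. Because the earlier step gave no change at the digits printed from compound 1 to compound 2 (within the scatter), the expected step is no change at the digits printed from compound 3 to compound 4 (within the scatter), small, though a base of zero leaves the size of that earlier step uncertain. Compound 4 is thus estimated at 42%, with a likely range from 22% to 62%.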

Compound 4, a percentage reported as inhibition, at one concentration (the size of the read-out at that concentration, not a potency): 29%
Estimate against measurement, compound 4: 13 percentage points above; low and high end bracket the measured number.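

Fluoro in place of hydrogen, phenylsulfanyl to (4-fluorophenyl)sulfanyl, gives a number 13 percentage points lower from compound 3 to compound 4 (beyond the scatter) in this assay. Set beside the same change on the other core, the two steps cannot be told apart: the same change on two cores in this assay, no change at the digits printed (within the scatter) from compound 1 to compound 2 and a number 13 percentage points lower (beyond the scatter) from compound 3 to compound 4, 13 percentage points apart, within the scatter of two such steps This shows nothing against the change carrying from one core to the other, but it does not show that the step has the same size on both, since each core offers a single pair and compound 1 starts from 0%, which leaves no room to see a loss. On these data alone, what an amine or a carboxylic acid in place of the fluoro would do on either core stays open. So does how each part of the difference between the two cores acts on the inhibition read-out.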